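Swapping the Ring on the Chain Carbon: Toxicity Outlook

A few compounds are considered here, and "the series" means these few. Any claim that something is new, unique, unknown or untested is made for them only; others in the source may bear on it.

Compound 1 (`COc1cccc(NC(=O)c2nnn(Cc3cc(C)on3)c2N)c1`) was tested in a toxicity assay on Vero cells (Chlorocebus sabaeus) for inhibition (a lower number here means that less compound is needed, a higher number that more compound is needed for the effect), and sits at the upper edge of what the test can report. In this assay compound 1 gives > 50100 nM as its read-out, and that value is a limit of the assay rather than a number. Compound 2 (`COc1cccc(NC(=O)c2nnn(Cc3ccc(C(C)C)cc3)c2N)c1`) gives > 50100 nM in this assay, which is likewise a limit. The step that the two limits leave unreadable from compound 1 to compound 2 is therefore unreadable in size, and the limit of > 50100 nM in this assay, at which 2 of the 2 values shown sit, shows both values resting at the same ceiling. Compound 3 (`COc1cccc(NC(=O)c2nnn(Cc3ccc(C4CC4)cc3)c2N)c1`) awaits measurement; its change from compound 1 is 4-cyclopropylphenyl in place of 5-methyl-1,2-oxazol-3-yl on a saturated chain carbon bound to an aromatic nitrogen in full. With only limits to draw on, no direction can be read from the known steps. Compound 3 is expected to give 50100 nM in this assay, within an estimated range from 25000 nM to 100000 nM overall. The expected step from compound 1 to compound 3 is a number no higher from compound 1 to compound 3 (the limit leaves the size open) at most, very likely reported again as a limit.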

Compound 3, half-maximal effective concentration in the Vero assay: > 50100 nM
Compound 3 gave a limit, no number; the forecaster's own chance of this, stated with the estimate: 85%; the middle value lies on the limit itself.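

Compound 1, compound 2 and compound 3 all stop at the same limit in the Vero assay, so no step between them can be read: the limit of > 50100 nM in the Vero assay, at which 3 of the 3 values shown sit.

In a physicochemical assay for lipophilicity, read by HPLC, measured as chromatographic lipophilicity, at pH 7.4 (a higher number here means a more lipophilic compound, a lower number a more polar compound), compound 1 gives 2 and compound 3 gives 3.2.

The compounds shown leave open at what concentration, if any, each would reach the half-maximal effect on these cells.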